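Thiomorpholine Analogue Expected Close to Its Morpholine Parent

The compounds below may be only part of what the source reports. "The series", "measured", "known", "first", "only" and "open" are said of these compounds alone.

Compound 2 `Cc1cccc(/C(N)=N/NC(=S)N2CCOCC2)n1` gives 21.6% in a functional assay on MCF7 cells (Homo sapiens) for cytotoxicity, read by MTT assay, with a stated time of 72 h, tested at 3 uM (on this read-out lower numbers stand for less inhibition of growth and higher numbers for more inhibition of growth at the one concentration tested), the lowest of the two numbers in hand, with compound 1 `Cc1cccc(/C(N)=N/NC(=S)N2CCCC2)n1` nearest at 26.6%. For the measured compounds named here, the only measured step, a number 5 percentage points lower from compound 1 to compound 2 (within the scatter), lies within the scatter. Compound 3 `Cc1cccc(/C(N)=N/NC(=S)N2CCSCC2)n1` differs from compound 2 by thiomorpholin-4-yl in place of morpholin-4-yl on a thiocarbonyl carbon. Going by the values given here, that earlier exchange of one saturated ring for another is the sole guide, and it shifted nothing beyond the scatter, so compound 3 is expected to show no real movement in this assay, a step of a number 2.4 percentage points higher from compound 2 to compound 3 (within the scatter). Compound 3 is estimated at 24%, within 12% to 38%.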

Compound 3, percent growth inhibition at one concentration: 20.6%
Estimate against measurement, compound 3: 3.4 percentage points above; the range from low to high includes it.
By their numbers in this assay, from the lowest: compounds 3, 2 and 1 (each within the scatter of the next).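

In this assay, thiomorpholin-4-yl in place of morpholin-4-yl on a thiocarbonyl carbon gives a number 1 percentage points lower from compound 2 to compound 3 (within the scatter) and thiomorpholin-4-yl in place of pyrrolidin-1-yl gives a number 6 percentage points lower from compound 1 to compound 3 (within the scatter) at the same place. The three saturated rings shown on this carbon therefore cannot be told apart in this read-out, and a sulfur in the ring adds no separation to what the oxygen ring showed. Nothing available bears on the reason for this. As far as these compounds go, whether a piperazin-1-yl ring with its free amine, or an open-chain dimethylamino group, would read differently on this carbon stays open. So does the effect of any change elsewhere on the shared core.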